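The source may report more compounds than this note shows. Statements on the series, on what has been measured and on what is new or still open speak of the compounds shown alone.

Measured in a functional assay on HT-29 cells (Homo sapiens) for cytotoxicity, read by MTT assay, with a stated time of 72 h; a higher number here means a weaker inhibitor, a lower number a stronger inhibitor:
- compound 1 `O=C(CN1CCN(c2nnc(Cc3ccncc3)c3ccccc23)CC1)Nc1cccc(F)c1`: 6130 nM
- compound 2 `Cc1ccc(F)cc1NC(=O)CN1CCN(c2nnc(Cc3ccncc3)c3ccccc23)CC1`: 470 nM
- compound 3 `O=C(CN1CCN(c2nnc(Cc3ccncc3)c3ccccc23)CC1)Nc1cc(C(F)(F)F)ccc1Cl`: 4810 nM

Among these three numbers, compound 3 stands at the high, weaker end, but it cannot be told apart from its nearest neighbour: a 1.3-fold lower number from compound 1 to compound 3 (0.11 log units; within the scatter). The low value is well clear of it: a 10-fold higher number from compound 2 to compound 3 (1.01 log units; beyond the scatter).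

The next compound is compound 4 `O=C(CN1CCN(c2nnc(Cc3ccncc3)c3ccccc23)CC1)Nc1c(F)cccc1F`. Here 2,6-difluorophenyl takes the place of 2-chloro-5-(trifluoromethyl)phenyl on an amide-type nitrogen: 2,6-difluorophenyl in place of 2-chloro-5-(trifluoromethyl)phenyl on an amide-type nitrogen.

All three measured steps change the group on this same nitrogen. One large step came with methyl in place of hydrogen on an aromatic carbon: a 13-fold lower number from compound 1 to compound 2 (1.12 log units; beyond the scatter). The other large step removes that methyl-bearing group again, while the swap between the two groups without methyl stayed within the scatter. Compound 4 also has no methyl, and its group carries only fluorine, like the 3-fluorophenyl of compound 1 at 6130 nM.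

Three compounds are a thin basis, but no step beyond the scatter is expected in this assay. The estimated change is small: a 1.4-fold lower number from compound 3 to compound 4 (0.14 log units; within the scatter).

For compound 4 the expected value is 3500 nM, with an estimated range of 900 nM to 10000 nM.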

Compound 4, half-maximal inhibitory concentration: 28700 nM
Estimate against measurement, compound 4: 8.2-fold (0.91 log units) below; measured number above the stated range.
By their numbers in this assay, from the lowest: compound 2; then compounds 3 and 1 (each within the scatter of the next); then compound 4.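

In this assay, among these compounds, the two groups without methyl on the amide-type nitrogen had so far been impossible to tell apart, but 2,6-difluorophenyl now separates clearly from both, with a 6.0-fold higher number from compound 3 to compound 4 (0.78 log units; beyond the scatter) and a 4.7-fold higher number from compound 1 to compound 4 (0.67 log units; beyond the scatter). Groups without methyl at this position therefore do not all sit at one level, and the range across this nitrogen is wider than the first three compounds showed, now reaching a 61-fold higher number from compound 2 to compound 4 (1.79 log units; beyond the scatter), which leaves compound 4 as the weakest of the four. Nothing measured here accounts for this change in the number.

Each step swaps several atoms at once, so these compounds cannot show whether the higher number of compound 4 belongs to its two fluorines or to the loss of the chlorine and trifluoromethyl of compound 3. Also open, as far as these compounds go, is where plain phenyl, or a phenyl ring carrying a methoxy group or an amine, would fall in this order, and whether any of them would come near the low number of compound 2.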